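Swapping the Sulfonyl Link for an Amide in Compound 4

This account rests on a few compounds, and the source may have more. Where it says the series, first, only, none or still open, it means among the compounds named here.

Compound 3 `COc1cc(N(Cc2nc3ccccc3[nH]2)S(=O)(=O)c2ccccc2)cc(OC)c1OC` is the starting point of this step. For the measured compounds named here, in a functional assay on PC-3 cells (Homo sapiens) for inhibition, read by MTT assay, with a stated time of 48 h (a higher number here means a weaker inhibitor, a lower number a stronger inhibitor), compound 3 gives 25500 nM, the highest of the two numbers measured so far. Compound 2 `COc1cc(N(Cc2cccc(C)c2)S(=O)(=O)c2ccc(C)cc2)cc(OC)c1OC` gives 8580 nM in this assay, a value that lies beyond the usual scatter from that of compound 3. Compound 1 `COc1ccc(CN(c2cc(OC)c(OC)c(OC)c2)S(=O)(=O)c2ccccc2)cc1` gives only a limit in this assay, > 50000 nM. Going by the values given here, the single measured step that changes one group at a time, an at least 1.9-fold lower number from compound 1 to compound 3 (0.29 log units; that floor lies within the scatter), can only be given as a floor because the limit of > 50000 nM in this assay, at which 1 of the 3 values shown sits, caps what was recorded for compound 1.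

Compound 4 `COc1cc(N(Cc2nc3ccccc3[nH]2)C(=O)c2ccc(C)cc2)cc(OC)c1OC` differs from compound 3 in one place: (4-methylphenyl)carbonyl in place of phenylsulfonyl on a nitrogen on an aromatic ring. Among the compounds with values here, no measured step touches this part of the molecule, so nothing here speaks directly to it. Compound 2 does carry a methyl on its sulfonyl-bearing ring, but it also carries a different benzyl group, so its value and that of compound 3 can only be set side by side, not read as a step. The expected change in this assay is therefore none beyond the scatter, a 1.3-fold lower number from compound 3 to compound 4 (0.11 log units; within the scatter). Compound 4 is estimated at 20000 nM, within a range from 5000 nM to 60000 nM.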

Compound 4, half-maximal inhibitory concentration: 42000 nM
The estimate for compound 4 lay 2.1-fold (0.32 log units) below the measured number, and the stated range covers the measured number.
By their numbers in this assay, from the lowest: compound 2; then compounds 3 and 4 (each within the scatter of the next). At a limit, above all of these: compound 1.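

In this assay, for the compounds shown here, the exchange on this nitrogen gives a 1.6-fold higher number from compound 3 to compound 4 (0.22 log units; within the scatter) and is the first measured step at this place, where the earlier compounds allowed only a side-by-side reading of values. The sulfonyl link can thus give way to a carbonyl link, with a methyl added to the ring at the same time, without a change beyond the scatter, even though the group that enters holds one double bond and one hydrogen-bond acceptor fewer outside and within the link than the group that leaves. Nothing measured here gives a reason for this result.

Compound 4 changes the link and the methyl together, so this single step cannot show what each edit does alone, and the two edits could be adding up or cancelling out. Also open, from the compounds shown here alone, is how this nitrogen would respond to a group of a quite different kind in the same place, such as a small acetyl, a urea link or a pyridine ring in place of the 4-methylphenyl.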